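A few compounds are considered here, and "the series" means these few. Any claim that something is new, unique, unknown or untested is made for them only; others in the source may bear on it.

Values in an assay on cell membranes with adenosine receptor A1 (Rattus norvegicus) as the target; on this read-out higher numbers stand for weaker inhibition and lower numbers for stronger inhibition:

compound 1, `CCCn1c(=O)c2c(ncn2C)n(C)c1=O`: 38000 nM
compound 2, `C=CCn1c(=O)c2c(ncn2C)n(C)c1=O`: 47000 nM
compound 3, `CCCn1c(=O)c2c(ncn2CCC)n(CCC)c1=O`: 2600 nM

Compound 1 and compound 2 share one core and differ by vinyl in place of ethyl on a saturated chain carbon bound to an aromatic nitrogen. The step is a 1.2-fold higher number from compound 1 to compound 2 (0.09 log units; within the scatter), so the two values cannot be ordered against each other. Compound 3 carries a different core; how it differs from compound 1 is not broken down here. Its number is the lowest of the three, and the gaps to compound 1 and to compound 2 are both beyond the scatter.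

Compound 4, `C=CCn1cnc2c1c(=O)n(CCC)c(=O)n2CCC`, stands to compound 3 as compound 2 stands to compound 1: it differs by vinyl in place of ethyl on a saturated chain carbon bound to an aromatic nitrogen, and the place is the same word for word, so this is the same change made on the core of compound 3. Among the measured compounds shown here, only one earlier instance of it exists, on the core of compound 1, and there it did nothing measurable. The expected step from compound 3 to compound 4 is therefore a 1.2-fold higher number from compound 3 to compound 4 (0.08 log units; within the scatter), resting on a 1.2-fold higher number from compound 1 to compound 2 (0.09 log units; within the scatter). For compound 4 in this assay the estimate is 3100 nM, with a range from 1500 nM to 6500 nM.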

Compound 4, inhibition constant: 1900 nM
For compound 4 the middle estimate is 1.6-fold (0.21 log units) above the measured one; measured number inside the range.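

In this assay, the change of propyl to allyl gives a 1.4-fold lower number from compound 3 to compound 4 (0.14 log units; within the scatter), so these two values cannot be ordered against each other. Set beside the earlier instance, the change reads alike on both cores: the same change on two cores in this assay, a 1.2-fold higher number (0.09 log units; within the scatter) from compound 1 to compound 2 and a 1.4-fold lower number (0.14 log units; within the scatter) from compound 3 to compound 4, 1.7-fold (0.23 log units) apart, within the scatter of two such steps. On these two cores the change therefore leaves the number within the scatter each time, but this is no evidence of a real effect in either direction, and two cores are too few to support a rule for the wider series.

The compounds shown leave open whether a longer chain, such as butyl, or a benzyl group in the same place would move the number beyond the scatter. They also leave open whether the change from propyl to allyl would stay within the scatter on a core carrying other groups, such as a longer chain or an amine, elsewhere.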